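Two chlorines on a fused core and cell toxicity

This account rests on a few compounds, and the source may have more. Where it says the series, first, only, none or still open, it means among the compounds named here.

Measured compounds:
compound 1 `ClCc1ccccc1Cn1cnc2c(Cl)nc(Cl)nc21` — 6310 nM
compound 2 `ClCc1ccccc1Cn1cnc2c(Cl)ncnc21` — > 100000 nM
compound 3 `ClCc1cccc(Cn2cnc3ncnc(Cl)c32)c1` — "not determined" (no result reported)

All three were tested in a functional assay on DU-145 cells (Homo sapiens) for cytotoxicity, read by sulforhodamine B assay, with a stated time of 48 h; on this read-out lower numbers stand for higher toxicity in this test and higher numbers for lower toxicity in this test. Compound 1 gives 6310 nM in this assay. For compound 2 this assay reports only a limit, > 100000 nM, and not a number (the limit of > 100000 nM in this assay, at which 1 of the 3 values shown sits). For compound 3 the result in this assay is "not determined" (no result reported).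

Compound 1 and compound 2 differ in one place: chloro in place of hydrogen on an aromatic carbon. This change brings an at least 15-fold lower number from compound 2 to compound 1 (1.19 log units; beyond the scatter), a large step.

Compound 3 shares its atoms with compound 2, but they are joined differently; the difference between the two cores is not broken down here.

The compound still to be measured is compound 4 `ClCc1cccc(Cn2cnc3nc(Cl)nc(Cl)c32)c1`. It differs from compound 3 by the same change: chloro in place of hydrogen on an aromatic carbon. Since compound 3 has no number in this assay, the expectation for compound 4 cannot be built as a step from it. It rests instead on compound 1, which carries the same two chloro groups and gives 6310 nM. Compound 2, which lacks one of them, gives in this assay only a limit and not a number. Compound 4 is expected to land in this assay near 7000 nM, estimated to fall between 2000 nM and 25000 nM.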

Compound 4, concentration lethal to 50% of the cells: 520 nM
Beside the measured number, compound 4's estimate is 13-fold (1.13 log units) above it; measured number outside the range, below it.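

No new step can be read: compound 3 has no result in this assay, so the change from compound 3 to compound 4 has no size, even though compound 4 gives 520 nM. The compounds shown leave open whether the added chloro group counts as much there as it does between compound 2 and compound 1, a step that rests on a limit: the limit of > 100000 nM in this assay, at which 1 of the 4 values shown sits.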